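The source may report more compounds than this note shows. Statements on the series, on what has been measured and on what is new or still open speak of the compounds shown alone.

Measured in a functional assay (brain) for inhibition, with Rattus norvegicus as the target; a lower number here means a stronger inhibitor, a higher number a weaker inhibitor:
compound 1 `Cc1c(C)c2c(c(C)c1O)CCC(C)(C(=O)NCc1cccnc1)O2`: 47000 nM
compound 2 `Cc1c(C)c2c(c(C)c1O)CCC(C)(C(=O)NCCCCc1ccccc1)O2`: 700 nM

Compound 2 holds the lower of the two numbers in this assay. Compound 3 `Cc1c(C)c2c(c(C)c1O)CCC(C)(C(=O)NCCN(C)C)O2` differs from it by dimethylamino in place of phenethyl on a saturated chain carbon, two bonds along the chain from an amide-type nitrogen. Among the compounds with values here, the only measured step bears on this: a 67-fold lower number from compound 1 to compound 2 (1.83 log units; beyond the scatter) shows that the group on this chain carbon moves the number greatly. Compound 3 carries no aromatic ring there and a shorter chain than either measured compound, so a large upward step is expected, a 29-fold higher number from compound 2 to compound 3 (1.46 log units; beyond the scatter). Compound 3 is estimated at 20000 nM, with a range from 5000 nM to 80000 nM.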

Compound 3, half-maximal inhibitory concentration: 8700 nM
Compound 3: middle estimate off by 2.3-fold (0.36 log units), on the high side, within the range that was stated.
By their numbers in this assay, from the lowest: compound 2; then compound 3; then compound 1.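

In this assay, the group on this chain carbon need not be aromatic to give a number well below that of compound 1: replacing pyridin-3-yl with (dimethylamino)methyl gives a 5.4-fold lower number from compound 1 to compound 3 (0.73 log units; beyond the scatter). An aromatic ring at this position therefore does not by itself give the lower number, since compound 1 carries one, although removing phenethyl still costs a 12-fold higher number from compound 2 to compound 3 (1.09 log units; beyond the scatter). No measurement here explains either step.

Chain length and end group change together across these compounds. A longer chain ending in dimethylamino, or a phenyl ring on the two-carbon chain, would separate the two.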